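From a Straight Butyl Chain to a Branched Isopentyl

The source may report more compounds than this note shows. Statements on the series, on what has been measured and on what is new or still open speak of the compounds shown alone.

Two compounds share one core. Compound 1, `Cc1ccccc1Cn1cnc(N)c2ncnc1-2`, gives 200 ug/mL in an assay on isolated protein (adrenal medulla) for inhibition of Dopamine beta-hydroxylase (Bos taurus); a higher number here means a weaker inhibitor, a lower number a stronger inhibitor. Compound 2, `CCCCn1cnc(N)c2ncnc1-2`, gives 20 ug/mL in this assay, the lower of the two numbers, and compound 1 stands well above it, beyond the scatter. Compound 3, `CC(C)CCn1cnc(N)c2ncnc1-2`, is not yet measured. It differs from compound 2 by methyl in place of hydrogen on a saturated chain carbon bound to two saturated chain carbons. Within the data shown here, no measured pair here shows this change, so its direction is unknown. The expected step from compound 2 to compound 3 is no change at the digits printed from compound 2 to compound 3 (within the scatter), not beyond the scatter. Compound 3 is therefore estimated at 20 ug/mL, between 8 ug/mL and 60 ug/mL.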

Compound 3, half-maximal inhibitory concentration: 200 ug/mL
Beside the measured number, compound 3's estimate is 10-fold (1.00 log units) below it; the whole stated range lies below it.
By their numbers in this assay, from the lowest: compound 2; then compounds 1 and 3 (each within the scatter of the next).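

In this assay, methyl in place of hydrogen on a saturated chain carbon bound to two saturated chain carbons gives a 10-fold higher number from compound 2 to compound 3 (1.00 log units; beyond the scatter) and so shows that this part of the chain does not tolerate every change. Turning butyl into isopentyl adds a single carbon, yet that is enough to weaken inhibition. No available evidence explains this loss.

On these data alone, it remains open whether the branch or the extra carbon matters, which a straight pentyl chain could help separate. An amine on this carbon is another untested possibility.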